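This account rests on a few compounds, and the source may have more. Where it says the series, first, only, none or still open, it means among the compounds named here.

Going by the values given here, compound 2 `COc1ccccc1/C=C/c1ccccc1F` gives 3100 nM in an assay on HepG2 cells for activation of nuclear factor erythroid 2-related factor 2 (Homo sapiens), read by a luciferase reporter, with a stated time of 5 h (on this read-out lower numbers stand for an effect already at smaller amounts and higher numbers for an effect only at larger amounts of compound), the highest of the two numbers measured so far. Among the compounds with values here, compound 1 `Fc1ccccc1/C=C/c1ccccc1` gives 700 nM, and the only measured step, a 4.4-fold higher number from compound 1 to compound 2 (0.65 log units; beyond the scatter), shows what the methoxy brought. Compound 3 `Fc1ccccc1/C=C/c1ccccc1F` differs from compound 2 by fluoro in place of methoxy on an aromatic carbon. Within the data shown here, no measured step tells what fluoro does at that carbon, so the expectation rests on the loss of the methoxy alone. For compound 3 the estimated step is a 3.4-fold lower number from compound 2 to compound 3 (0.54 log units; beyond the scatter). Compound 3 is therefore estimated at 900 nM, in a range from 400 nM to 2500 nM.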

Compound 3, half-maximal effective concentration: 4300 nM
The estimate for compound 3 lay 4.8-fold (0.68 log units) below the measured number; measured number above the stated range.
By their numbers in this assay, from the lowest: compound 1; then compounds 2 and 3 (each within the scatter of the next).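

In this assay fluoro in place of methoxy on this aromatic carbon gives a 1.4-fold higher number from compound 2 to compound 3 (0.14 log units; within the scatter) and so does not separate the two groups. Fluoro in place of hydrogen gives a 6.1-fold higher number from compound 1 to compound 3 (0.79 log units; beyond the scatter) and thus, like methoxy, goes with a higher number than hydrogen at this carbon, so the earlier rise is not peculiar to methoxy. Nothing measured here gives a reason for this. From the compounds shown here alone, whether an amine or a carboxylic acid on this carbon would also stay with the higher numbers remains open. So does what fluoro or methoxy would do at any other carbon of the core.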